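Swapping a pyridine for a fluorinated pyridyl ether

A few compounds are considered here, and "the series" means these few. Any claim that something is new, unique, unknown or untested is made for them only; others in the source may bear on it.

Of the compounds shown here, three built on one shared core have been tested in a functional assay on CHO cells for positive allosteric modulation of muscarinic acetylcholine receptor M5 (Homo sapiens), read by FLIPR and calcium flux, with a stated time of 1 h; a lower number here means that less compound is needed, a higher number that more compound is needed for the effect. Compound 1 `O=C1C(=O)N(Cc2ccc(-c3cncnc3)cc2)c2ccc(OC(F)(F)F)cc21` gives 2100 nM, compound 2 `O=C1C(=O)N(Cc2ccc(Oc3ccccn3)cc2)c2ccc(OC(F)(F)F)cc21` gives 3200 nM, and compound 3 `O=C1C(=O)N(Cc2ccc(-c3ccncc3)cc2)c2ccc(OC(F)(F)F)cc21` gives 2800 nM. Compound 3 has the second highest of these three numbers, and all three lie within the scatter of one another: a 1.3-fold higher number from compound 1 to compound 3 (0.12 log units; within the scatter), a 1.5-fold higher number from compound 1 to compound 2 (0.18 log units; within the scatter), and a 1.1-fold lower number from compound 2 to compound 3 (0.06 log units; within the scatter). Compound 4 `O=C1C(=O)N(Cc2ccc(Oc3cccc(F)n3)cc2)c2ccc(OC(F)(F)F)cc21` is not yet measured; it arises from compound 3 by (6-fluoropyridin-2-yl)oxy in place of pyridin-4-yl on an aromatic carbon. The most relevant earlier step exchanged the same two kinds of group, only without the fluorine, and stayed within the scatter: a 1.1-fold lower number from compound 2 to compound 3 (0.06 log units; within the scatter). No step beyond the scatter is therefore expected: a 1.1-fold higher number from compound 3 to compound 4 (0.03 log units; within the scatter). Compound 4 is estimated at 3000 nM, with a range from 1400 nM to 6500 nM.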

Compound 4, half-maximal effective concentration: 1500 nM
Compound 4: the middle estimate sits 2.0-fold (0.30 log units) above what was measured; measured number inside the range.
By their numbers in this assay, from the lowest: compounds 4, 1, 3 and 2 (each within the scatter of the next, the first and the last beyond it).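

In this assay, among these compounds, fluoro in place of hydrogen on the pyridyl ether gives the only step from this result that lies beyond the scatter, though a modest one (a 2.1-fold lower number from compound 2 to compound 4 (0.33 log units; beyond the scatter)). Exchanging the whole aromatic group at this position, para to a large group, stays within the scatter (a 1.9-fold lower number from compound 3 to compound 4 (0.27 log units; within the scatter); a 1.4-fold lower number from compound 1 to compound 4 (0.15 log units; within the scatter)). Nothing measured here gives a reason for the fluoro step.

Going by these compounds, whether chloro, methyl or methoxy in place of that fluoro would give a similar number remains open. So does the effect of fluoro on the pyridin-4-yl group.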